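A few compounds are considered here, and "the series" means these few. Any claim that something is new, unique, unknown or untested is made for them only; others in the source may bear on it.

Measured so far in an assay on cells for displacement of a labelled ligand from transmembrane domain-containing protein TMIGD3 (Homo sapiens), read by scintillation counting, with a stated time of 120 min, tested at 1 uM; a higher number here means more inhibition at the concentration tested (going by the name of the read-out), a lower number less inhibition:
compound 1 `Nc1nc(-c2ccccc2)cn2cc(-c3ccccc3)nc12`, 23%
compound 2 `COc1cccc(-c2cn3cc(-c4ccccc4)nc3c(N)n2)c1`, 21%

Compound 2 stands within the scatter of compound 1: the step of a number 2 percentage points lower from compound 1 to compound 2 (within the scatter) is too small to separate the two, so these two numbers give no ranking at all, only a level of modest inhibition shared by both. Compound 3 `Nc1nc(-c2cccc(C(=O)O)c2)cn2cc(-c3ccccc3)nc12` is the next member to be measured. It differs from compound 2 by carboxy in place of methoxy on an aromatic carbon. Among the compounds with values here, the only measured step, a number 2 percentage points lower from compound 1 to compound 2 (within the scatter), concerns a different group entering on an aromatic carbon and stayed within the scatter; no measured pair involves a carboxy group. Within the data shown here, with that single flat step as the only guide, the expected step is about a number 2 percentage points lower from compound 2 to compound 3 (within the scatter), within the scatter and in no settled direction. Compound 3 is therefore estimated at 19% in this assay, with a range from 3% to 36%.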

Compound 3, a percentage reported as inhibition, at one concentration (the size of the read-out at that concentration, not a potency): 1%
Compound 3: middle estimate off by 18 percentage points, on the high side; the whole stated range lies above it.
By their numbers in this assay, from the lowest: compound 3; then compounds 2 and 1 (each within the scatter of the next).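

In this assay this position, an aromatic carbon of a six-membered aromatic ring of carbon only, meta to a large group, is not indifferent to what it carries, although methoxy there left the number within the scatter. Carboxy in place of methoxy gives a number 20 percentage points lower from compound 2 to compound 3 (beyond the scatter) and carboxy in place of hydrogen gives a number 22 percentage points lower from compound 1 to compound 3 (beyond the scatter) in the same series, so both comparisons set compound 3 apart and the drop follows the carboxy group, not substitution at this place as such. No measurement at hand bears on what lies behind this drop.

From the compounds shown here alone, whether a methyl ester, a primary amide or an aminomethyl group at this place would stay level with compound 1 or fall with compound 3 remains open. Also open, going by these compounds, is whether a carboxy group elsewhere on the shared core gives the same drop.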